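Difluorophenyl for chlorophenyl on the shared pyridazinone nitrogen

The source may hold more compounds than are shown below. What is called first, only, known or untested is meant among the compounds shown, and "the series" means these compounds.

Compound 3 `COc1cc2c(Oc3ccc(NC(=O)c4nn(-c5ccc(Cl)cc5)c(=O)cc4C)cc3F)ccnc2cc1OCCCN1CCN(C)CC1` gives 440 nM in a functional assay on NCI-H460 cells (Homo sapiens) for inhibition, read by MTT assay, with a stated time of 72 h; on this read-out higher numbers stand for weaker inhibition and lower numbers for stronger inhibition. Among the three measured compounds it holds the second highest number: compound 2 `COc1cc2c(Oc3ccc(NC(=O)c4nn(-c5ccccc5OC(F)(F)F)c(=O)cc4C)cc3F)ccnc2cc1OCCCN1CCN(C)CC1` gives 260 nM, and compound 1 `COc1cc2c(Oc3ccc(NC(=O)c4nn(-c5ccccc5C)c(=O)cc4C)cc3F)ccnc2cc1OCCCN1CCN(C)CC1` gives 3420 nM. The step of a 1.7-fold higher number from compound 2 to compound 3 (0.23 log units; within the scatter) lies within the scatter, whereas the step of a 7.8-fold lower number from compound 1 to compound 3 (0.89 log units; beyond the scatter) is a clear gain, as is a 13-fold lower number from compound 1 to compound 2 (1.12 log units; beyond the scatter).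

Compound 4 `COc1cc2c(Oc3ccc(NC(=O)c4nn(-c5ccc(F)c(F)c5)c(=O)cc4C)cc3F)ccnc2cc1OCCCN1CCN(C)CC1` differs from compound 3 in one place: 3,4-difluorophenyl in place of 4-chlorophenyl on an aromatic nitrogen. Among the measured compounds shown here, no measured step swaps one halogen-bearing phenyl for another; the only steps that touch compound 3 are a 7.8-fold lower number from compound 1 to compound 3 (0.89 log units; beyond the scatter) and a 1.7-fold higher number from compound 2 to compound 3 (0.23 log units; within the scatter), and both replace a 2-substituted phenyl rather than the 4-chlorophenyl that leaves here. Because the aryl groups of compound 2 and compound 3 gave a 1.7-fold higher number from compound 2 to compound 3 (0.23 log units; within the scatter), a second ring that keeps a halogen is expected to stay in the same region. Compound 4 is therefore expected to move by a 1.2-fold higher number from compound 3 to compound 4 (0.07 log units; within the scatter), not beyond the scatter. The estimated value of compound 4 in this assay is 520 nM, within 200 nM to 1400 nM.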

Compound 4, half-maximal inhibitory concentration: 190 nM
Estimate against measurement, compound 4: 2.7-fold (0.44 log units) above, and the stated range ends above it.
By their numbers in this assay, from the lowest: compounds 4, 2 and 3 (each within the scatter of the next, the first and the last beyond it); then compound 1.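

In this assay, among the compounds shown here, the exchange of 4-chlorophenyl for 3,4-difluorophenyl on the aromatic nitrogen gives a 2.3-fold lower number from compound 3 to compound 4 (0.36 log units; beyond the scatter) and is the first measured step between two halogen-bearing phenyl groups, so the number at this position still changes when a halogen stays on the ring. Set against 2-(trifluoromethoxy)phenyl the same ring shows a 1.4-fold lower number from compound 2 to compound 4 (0.14 log units; within the scatter) and set against 2-methylphenyl it shows an 18-fold lower number from compound 1 to compound 4 (1.26 log units; beyond the scatter), which leaves 2-methylphenyl as the one clear outlier among the four aryl groups. Nothing measured here offers a reason for these steps.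

From the compounds shown here alone, it remains open whether the change follows from the two fluorines together or from the loss of chlorine, a question that a phenyl ring carrying a single fluorine could help to separate. Going by these compounds, how a pyridyl ring or a phenyl ring bearing an amine would read on this nitrogen also stays open.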